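Swapping dichlorophenyl for fluorophenyl on the sulfur

The source may hold more compounds than are shown below. What is called first, only, known or untested is meant among the compounds shown, and "the series" means these compounds.

Compound 3 `Nc1cc(N)c2nc(-c3ccccc3)c(Sc3ccc(Cl)c(Cl)c3)nc2c1` gives 34700 nM in a functional assay on NCI-H23 cells (Homo sapiens) for inhibition, read by sulforhodamine B assay, with a stated time of 48 h (on this read-out higher numbers stand for weaker inhibition of growth and lower numbers for stronger inhibition of growth), the higher of the two readable numbers. Compound 1 `Nc1cc(N)c2nc(-c3ccccc3)c(NCc3ccc(F)cc3)nc2c1` gives 4570 nM, and the step of a 7.6-fold higher number from compound 1 to compound 3 (0.88 log units; beyond the scatter) is the only one whose size can be read. Compound 2 `COc1ccc(Sc2nc3cc(N)cc(N)c3nc2-c2ccccc2)cc1` gives only a limit of the assay, < 100000 nM. Because of that limit (the limit of < 100000 nM in this assay, at which 1 of the 3 values shown sits), the steps a step that the limit leaves unreadable from compound 1 to compound 2 and a step that the limit leaves unreadable from compound 2 to compound 3 cannot be sized. Compound 4 `Nc1cc(N)c2nc(-c3ccccc3)c(Sc3ccc(F)cc3)nc2c1` differs from compound 3 by 4-fluorophenyl in place of 3,4-dichlorophenyl on a sulfur. For the measured compounds named here, no measured step changes the group on the sulfur with a readable size, so the expectation rests on compound 3 alone. A step of a 1.2-fold lower number from compound 3 to compound 4 (0.06 log units; within the scatter) is expected, which is within the usual scatter. Compound 4 is therefore estimated at 30000 nM, with a range from 8000 nM to 100000 nM.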

Compound 4, concentration for total growth inhibition: 39800 nM
Beside the measured number, compound 4's estimate is 1.3-fold (0.12 log units) below it; low and high end bracket the measured number.
By their numbers in this assay, from the lowest: compound 1; then compounds 3 and 4 (each within the scatter of the next).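

In this assay, for the compounds shown here, a 1.1-fold higher number from compound 3 to compound 4 (0.06 log units; within the scatter), so on this sulfur 4-fluorophenyl and 3,4-dichlorophenyl cannot be told apart, the first readable comparison of groups there. Putting (4-fluorophenyl)sulfanyl in place of (4-fluorobenzyl)amino gives an 8.7-fold higher number from compound 1 to compound 4 (0.94 log units; beyond the scatter), the same direction as the step to (3,4-dichlorophenyl)sulfanyl. Steps involving compound 2 cannot be read because its value is a limit: the limit of < 100000 nM in this assay, at which 1 of the 4 values shown sits.

As far as these compounds go, it remains open whether an amine or a carboxylic acid on that phenyl ring would move the number. Also open, from the compounds shown here alone, is what a longer alkyl chain on the sulfur would do.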